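A few compounds are considered here, and "the series" means these few. Any claim that something is new, unique, unknown or untested is made for them only; others in the source may bear on it.

Working notes on the series. Of the compounds shown here, two have been measured in an assay on HEK293T cells for inhibition, read by scintillation counting, with stated times of 5 min and 15 min, at pH 5.5; on this read-out higher numbers stand for weaker inhibition and lower numbers for stronger inhibition. Compound 1, `Cc1nn(-c2ccccn2)c(O)c1C(=O)Nc1cccc(C(F)(F)F)c1`, gives in this assay only a limit, > 10000 nM; this is the limit of > 10000 nM in this assay, at which 1 of the 2 values shown sits, and no number is attached to it. Among the compounds with values here, compound 2, `Cc1cc(=O)[nH]c(-n2nc(C)c(C)c2C)n1`, gives in this assay a value of 10000 nM, which is the only number so far in the set. Within the data shown here, the other entry is the one just described for compound 1. Compound 2 therefore stands at the weak end of what this read-out resolves, with no second number to compare it against.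

Compound 3, `CCc1c(C)nn(-c2nc(C)cc(=O)[nH]2)c1C`, is not yet measured. It differs from compound 2 by methyl in place of hydrogen on a saturated chain carbon bound to an aromatic carbon. Among the measured compounds shown here, no step between two measured compounds is available to calibrate a change of this kind, so the expectation rests on the size of the change alone: one carbon added to a saturated chain, no ring, no donor or acceptor. The step from compound 2 to compound 3 in this assay is expected to be no change at the digits printed from compound 2 to compound 3 (within the scatter), that is, no shift beyond the scatter in either direction. Compound 3 is estimated to give 10000 nM in this assay, within a range of 4000 nM to 25000 nM, with a fair chance that only a limit is reported.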

Compound 3, half-maximal inhibitory concentration: 4200 nM
For compound 3 the middle estimate is 2.4-fold (0.38 log units) above the measured one; measured number inside the range.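

Within the data shown here, the saturated chain carbon bound to an aromatic carbon is the first place where a change can be read, and in this assay the series shows a 2.4-fold lower number from compound 2 to compound 3 (0.38 log units; beyond the scatter). This position therefore responds to the read-out: methyl to ethyl, with no ring, no donor or acceptor and no net charge entering, is enough to move the number modestly beyond the scatter, and the direction is towards stronger inhibition. Compound 1 gives no comparison with this step, as it differs from compound 3 in more than one place and its entry is a limit, not a number: the limit of > 10000 nM in this assay, at which 1 of the 3 values shown sits.

As far as these compounds go, a single step at a single position gives no trend, so it remains open whether a longer chain such as propyl, a branched chain such as isopropyl, or an ethyl chain ending in an amine or a hydroxyl would lower the number further, hold it or reverse it. It also remains open whether the same methyl for hydrogen change would have any effect elsewhere on the shared core, and the compounds shown give no cause for the step.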